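The compounds below may be only part of what the source reports. "The series", "measured", "known", "first", "only" and "open" are said of these compounds alone.

Values so far in a functional assay on M21 cells (Homo sapiens) for inhibition, read by sulforhodamine B assay, with a stated time of 48 h; on this read-out lower numbers stand for stronger inhibition of growth and higher numbers for weaker inhibition of growth:
- compound 1 `O=C(CCl)NC(=O)Nc1ccc(-c2ccccc2)cc1`: 1400 nM
- compound 2 `O=C(CCl)NC(=O)Nc1ccc(OC2CCCC2)cc1`: 2900 nM
- compound 3 `O=C(CCl)NC(=O)Nc1cccc(OC2CCCC2)c1`: 3500 nM

Compound 3 and compound 2 lie within the scatter of each other, and both numbers stand higher than that of compound 1. Compound 4 `O=C(CCl)NC(=O)Nc1cccc(OCc2ccccc2)c1` carries benzyl in place of cyclopentyl on an oxygen on an aromatic ring. Within the data shown here, one measured step bears on this, cyclopentyloxy in place of phenyl on an aromatic carbon, with a 2.1-fold higher number from compound 1 to compound 2 (0.32 log units; beyond the scatter), which is modest. It is only a loose guide, as compound 4 keeps the oxygen that compound 1 lacks. Among the measured compounds shown here, a small drop, no larger than that step, is therefore expected in this assay. The expected change is a 1.6-fold lower number from compound 3 to compound 4 (0.20 log units; within the scatter), which stays within the scatter. For compound 4 the estimate is 2200 nM, with an expected range from 900 nM to 5000 nM.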

Compound 4, concentration for 50% growth inhibition: 4500 nM
The estimate for compound 4 lay 2.0-fold (0.31 log units) below the measured number; the range from low to high includes it.
By their numbers in this assay, from the lowest: compound 1; then compounds 2, 3 and 4 (each within the scatter of the next).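

Read in this assay the exchange on the oxygen on an aromatic ring gives a 1.3-fold higher number from compound 3 to compound 4 (0.11 log units; within the scatter) and so stays within the scatter. At this oxygen, a six-membered aromatic ring of carbon held on benzyl and a five-membered non-aromatic ring in cyclopentyl give no separable difference. No measurement at hand accounts for this flat step.

As far as these compounds go, whether an amine or a carboxylic acid on the benzyl ring, or a longer chain on the oxygen, would move the number beyond the scatter remains open. Also open, from the compounds shown here alone, is whether benzyl would behave alike at the ring place that cyclopentyloxy holds in compound 2.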